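Cyclopropyl for methyl on the core of compound 2

The compounds below may be only part of what the source reports. "The series", "measured", "known", "first", "only" and "open" are said of these compounds alone.

In a functional assay on HCT-116 cells (Homo sapiens) for antiproliferative activity, read by MTT assay, with a stated time of 72 h (a higher number here means a weaker inhibitor, a lower number a stronger inhibitor), compound 2 `COc1c(NS(=O)(=O)c2ccc(F)cc2)cc(-c2ccn3nc(NC(C)=O)nc3c2)cc1C(N)=O` gives 32600 nM, the highest of the three numbers measured. Compound 1 `COc1c(NS(=O)(=O)c2ccc(F)cc2)cc(-c2ccc3nc(NC(C)=O)sc3c2)cc1C(N)=O` gives 1950 nM and compound 3 `COc1c(NS(=O)(=O)c2ccc(F)cc2)cc(-c2ccc3nc(NC(=O)C4CC4)sc3c2)cc1C(N)=O` gives 2010 nM, each lying beyond the scatter from compound 2. Compound 4 `COc1c(NS(=O)(=O)c2ccc(F)cc2)cc(-c2ccn3nc(NC(=O)C4CC4)nc3c2)cc1C(N)=O` differs from compound 2 by cyclopropyl in place of methyl on a carbonyl carbon. Going by the values given here, the one measured step that bears on this change, a 1.0-fold higher number from compound 1 to compound 3 (0.01 log units; within the scatter), made the same exchange on the core of compound 1 and left the number essentially where it was. On that basis the step of a 1.0-fold lower number from compound 2 to compound 4 (0.01 log units; within the scatter) is expected to stay within the scatter, with no clear direction. Compound 4 is therefore estimated at 32000 nM in this assay, with a range from 12000 nM to 85000 nM.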

Compound 4, half-maximal inhibitory concentration: > 50000 nM
Compound 4 gave a limit, no number; the forecaster's own chance of this, stated with the estimate: 5%; at least 1.5-fold (0.19 log units) between middle value and limit.
By their numbers in this assay, from the lowest: compounds 1 and 3 (each within the scatter of the next); then compound 2. At a limit, above all of these: compound 4.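

In this assay compound 4 reaches only a limit of the assay, > 50000 nM, and not a number. On these data alone, the step reads an at least 1.5-fold higher number from compound 2 to compound 4 (0.18 log units; that floor lies within the scatter), so on this core cyclopropyl in place of methyl on the carbonyl carbon brings no gain in strength, while the true size of the step stays unknown. Set side by side, the two cores give this: the same change on two cores in this assay, a 1.0-fold higher number (0.01 log units; within the scatter) from compound 1 to compound 3 and an at least 1.5-fold higher number (0.18 log units; that floor lies within the scatter) from compound 2 to compound 4; the limit leaves it open whether they differ

The compounds shown leave open how a longer chain or an amine on this carbonyl carbon would read on either core.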